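The source may report more compounds than this note shows. Statements on the series, on what has been measured and on what is new or still open speak of the compounds shown alone.

Three compounds share one core, an amide that joins a chlorinated ring to a second aromatic ring. Compound 1 `Cc1nc(C(F)(F)F)ccc1C(=O)Nc1ccc(Cl)c(-c2cn3ccsc3n2)c1` gives 200 nM in an assay on C3H 10T1/2 cells for inhibition of Sonic hedgehog protein (Mus musculus), read by a luciferase reporter; a lower number here means a stronger inhibitor, a higher number a weaker inhibitor. Compound 2 `Cc1nc(C(F)(F)F)ccc1C(=O)Nc1ccc(Cl)c(-c2ncccn2)c1` gives 8000 nM in this assay, and the step of a 40-fold higher number from compound 1 to compound 2 (1.60 log units; beyond the scatter) shows how much the ring on the aromatic carbon matters. Compound 3 `Cc1ccc(C(=O)Nc2ccc(Cl)c(-c3ccccn3)c2)c(C)n1` gives 130 nM in this assay; among the three numbers it is the lowest, its gap to compound 1 lying within the scatter while its gap to compound 2 lies far beyond it.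

Compound 4 `O=C(Nc1ccc(Cl)c(-c2ccccn2)c1)c1ccncc1` differs from compound 3 on the other side of the amide: pyridin-4-yl in place of 2,6-dimethylpyridin-3-yl on a carbonyl carbon. Within the data shown here, the only measured step, a 40-fold higher number from compound 1 to compound 2 (1.60 log units; beyond the scatter), concerns the ring on the aromatic carbon, not the ring on the carbonyl carbon, so no measured step bears directly on this change. Among the measured compounds shown here, with no precedent, a modest weakening is expected for compound 4, a step of a 4.6-fold higher number from compound 3 to compound 4 (0.66 log units; beyond the scatter), though a step within the scatter would not surprise. Compound 4 is therefore estimated at 600 nM in this assay, with a range from 150 nM to 2500 nM.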

Compound 4, half-maximal inhibitory concentration: 700 nM
Estimate against measurement, compound 4: 1.2-fold (0.07 log units) below; low and high end bracket the measured number.
By their numbers in this assay, from the lowest: compounds 3 and 1 (each within the scatter of the next); then compound 4; then compound 2.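

Among these compounds, compound 4 gives the first measured step on the carbonyl side of the amide, with the rest of the molecule unchanged: pyridin-4-yl in place of 2,6-dimethylpyridin-3-yl on a carbonyl carbon gives a 5.4-fold higher number from compound 3 to compound 4 (0.73 log units; beyond the scatter) in this assay. The ring on the carbonyl carbon therefore also affects the inhibitor's strength, not only the ring on the aromatic carbon, and this modest step combines two changes: the two methyl groups go, and the pyridine attachment changes from 3-yl to 4-yl. No available evidence explains the weakening.

The compounds shown do not separate the loss of the methyl groups from the change in attachment. On these data alone, how an amine or a carboxylic acid on this ring would read in this assay also remains open.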